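Exchanging the Amide Aryl Group on a Shared Core

The compounds below may be only part of what the source reports. "The series", "measured", "known", "first", "only" and "open" are said of these compounds alone.

Compound 1, `Cc1cnc(NC(=O)COc2ccc(/C=C3\SC(=O)NC3=O)cc2)s1`, gives 37200 nM; 2240 nM (2 entries) in a functional assay on PC-3 cells (Homo sapiens) for cytotoxicity, read by sulforhodamine B assay, with a stated time of 48 h; a lower number here means a stronger inhibitor of growth, a higher number a weaker inhibitor of growth. Compound 2, `O=C(COc1ccc(/C=C2\SC(=O)NC2=O)cc1)Nc1ncc([N+](=O)[O-])s1`, shows only a limit in this assay, < 100000 nM. Compound 3, `O=C(COc1ccc(/C=C2\SC(=O)NC2=O)cc1)Nc1ccccn1`, gives 29500 nM in this assay.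

Among the measured compounds shown here, compound 3 thus stands as the only plain number; compound 1 is known through (the several entries of compound 1 in this assay, 37200 nM; 2240 nM (2 entries)), and compound 2 only through (the limit of < 100000 nM in this assay, at which 1 of the 3 values shown sits). The step that the limit leaves unreadable from compound 2 to compound 3 is therefore unreadable in size. Compound 4, `Cc1cc(NC(=O)COc2ccc(/C=C3\SC(=O)NC3=O)cc2)no1`, carries the change (5-methyl-1,2-oxazol-3-yl in place of pyridin-2-yl on an amide-type nitrogen). No readable step bears on this exchange, so the expectation for compound 4 is a step of a 1.0-fold higher number from compound 3 to compound 4 (0.01 log units; within the scatter) of no size beyond the scatter. Compound 4 is accordingly estimated at 30000 nM, within 8000 nM to 100000 nM.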

Compound 4, concentration for 50% growth inhibition: < 100000 nM
Compound 4 ended at the assay's limit; the forecaster's own chance of this, stated with the estimate: 20%; the middle value lies beyond the limit too.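

Among the compounds shown here, compound 4 gives only a limit, < 100000 nM, in this assay, so no step to it from compound 2 or compound 3 can be read. Whether the amide aryl exchange among these three compounds changes growth inhibition at all remains open.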